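A Chain Extension Tested Against a Dosing Limit

The compounds below may be only part of what the source reports. "The series", "measured", "known", "first", "only" and "open" are said of these compounds alone.

Compound 1 `C/N=C(\S)NCCCCn1nc(C)ccc1=O`: in a functional assay on the whole organism (stomach) with Rattus norvegicus as the target (a lower number here means that less compound is needed, a higher number that more compound is needed for the effect), a limit of > 100 mg/kg
Compound 2 `C/N=C(/NC#N)NCCCn1nc(-c2ccccc2)ccc1=O`: in this assay a limit of > 100 mg/kg

Compound 2 stands at a limit of the assay rather than at a number, because of the limit of > 100 mg/kg in this assay, at which 2 of the 2 values shown sit. Among the measured compounds shown here, no step between measured compounds exists, so no size of effect for any change has been seen. Compound 3 `N#CNC(=N)NCCCCCn1nc(-c2ccccc2)ccc1=O` differs from compound 2 by a group of 8 heavy atoms (4 carbon, 4 nitrogen; no ring) in place of a group of 7 heavy atoms (3 carbon, 4 nitrogen; no ring), on a saturated chain carbon, three bonds along the chain from an aromatic nitrogen. Compound 3 is expected to remain at the limit, with an estimate of 200 mg/kg (between 50 mg/kg and 1000 mg/kg). This estimate means an expected step that the limit leaves unreadable from compound 2 to compound 3, none beyond the scatter.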

Compound 3, dose for half-maximal effect: > 100 mg/kg
Compound 3: only a limit was reported (the forecaster's own chance of this, stated with the estimate: 80%); the middle value is on the limit's open side.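

In this assay compound 3 also gives only a limit, > 100 mg/kg. No step can be read from compound 2 to compound 3, because both values are limits: the limit of > 100 mg/kg in this assay, at which 3 of the 3 values shown sit.

Going by these compounds, how the group of 8 heavy atoms compares with the group of 7 heavy atoms in this assay stays open.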